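Tetrazole for carboxylate in a leukotriene receptor antagonist series

The compounds below may be only part of what the source reports. "The series", "measured", "known", "first", "only" and "open" are said of these compounds alone.

Compound 1 `CCCc1c(COc2ccc(C(=O)CCC(=O)O)cc2)ccc(C(C)=O)c1O`: 18.2 mg/kg
Compound 2 `CCCc1c(COc2ccc(C(=O)CCc3nnn[nH]3)cc2)ccc(C(C)=O)c1O`: 10.1 mg/kg
Compound 3 `CCCc1c(COc2ccc(C(=O)C(C)(C)Cc3nnn[nH]3)cc2)ccc(C(C)=O)c1O`: 10.8 mg/kg

In an in vivo functional assay on the whole organism (Rattus norvegicus) with cysteinyl leukotriene receptor (Homo sapiens) as the target (on this read-out higher numbers stand for an effect only at larger amounts of compound and lower numbers for an effect already at smaller amounts), compound 1 gives the largest of the three numbers, but its steps to compound 2 and compound 3 both fall within the scatter. Compound 4 `CCCc1c(COc2ccc(C(=O)CC(C)(C)Cc3nnn[nH]3)cc2)ccc(C(C)=O)c1O` differs from compound 1 in one place: 1-((1H-tetrazol-5-yl)methyl)-1-methylethyl in place of carboxymethyl on a saturated chain carbon bound to a carbonyl carbon. For the measured compounds named here, two measured steps bear on this change, as each replaces the carboxy group of compound 1 with a tetrazole: a 1.8-fold lower number from compound 1 to compound 2 (0.26 log units; within the scatter) and a 1.7-fold lower number from compound 1 to compound 3 (0.23 log units; within the scatter). Neither moved the number beyond the scatter, and the step from compound 2 to compound 3 was a 1.1-fold higher number from compound 2 to compound 3 (0.03 log units; within the scatter). Compound 4 is therefore expected to sit close to compound 1, perhaps slightly lower, at 12 mg/kg within a range of 6 mg/kg to 25 mg/kg, a step of a 1.5-fold lower number from compound 1 to compound 4 (0.18 log units; within the scatter).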

Compound 4, dose for half-maximal effect: 1.3 mg/kg
Compound 4: the middle estimate sits 9.2-fold (0.97 log units) above what was measured; the measured number lies below the stated range.
By their numbers in this assay, from the lowest: compound 4; then compounds 2, 3 and 1 (each within the scatter of the next).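

In this assay a tetrazole end group moved the number beyond the scatter only with 1-((1H-tetrazol-5-yl)methyl)-1-methylethyl on the saturated chain carbon bound to a carbonyl carbon, giving a 14-fold lower number from compound 1 to compound 4 (1.15 log units; beyond the scatter) against the carboxy compound. The two methyl groups count at this place: this group in place of (1H-tetrazol-5-yl)methyl gives a 7.8-fold lower number from compound 2 to compound 4 (0.89 log units; beyond the scatter). Their place on the chain counts too: 2-((1H-tetrazol-5-yl)methyl)-2-methylpropyl on the carbonyl carbon gives an 8.3-fold lower number from compound 3 to compound 4 (0.92 log units; beyond the scatter). Nothing available explains the gain. On these data alone, whether a carboxylic acid on the same branched chain, or a longer chain, would give a similar number stays open.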